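Series notes: ring swap on the aromatic nitrogen of compound 3

The source may hold more compounds than are shown below. What is called first, only, known or untested is meant among the compounds shown, and "the series" means these compounds.

The set so far holds three measured compounds. Compound 1 `O=C(Cn1nnc(-c2ccccc2)n1)NC1CC2CCC1C2` gives 13% in an assay on HEK293 cells for activation of Kir3.1/Kir3.2 (Homo sapiens), read by thallium flux; on this read-out lower numbers stand for smaller maximal responses and higher numbers for larger maximal responses. Compound 2 `Cc1cc(NC(=S)Cn2nnc(-c3ccccc3)n2)n(C2CCCCC2)n1` gives 80% in this assay. Compound 3 `Cc1cc(NC(=O)Cn2nnc(-c3ccccc3)n2)n(C2CCOCC2)n1` gives 115% in this assay, the highest value of the three, with compound 2 the nearest and compound 1 the furthest, both gaps beyond the scatter. No pair of these compounds differs in a single place, so no measured step is available to anchor the next change.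

Compound 4 `Cc1cc(NC(=O)Cn2nnc(-c3ccccc3)n2)n(C2CCC(C)(C)CC2)n1` is the next compound to be measured. It differs from compound 3 as follows: 4,4-dimethylcyclohexyl in place of oxan-4-yl on an aromatic nitrogen. Within the data shown here, no measured step covers this kind of change, so the expectation rests only on the high value of compound 3 and on compound 2, which carries a carbon-only six-membered ring on the same aromatic nitrogen and gives a lower value. A modest decrease is expected, a number 20 percentage points lower from compound 3 to compound 4 (beyond the scatter), possibly not beyond the scatter. Compound 4 is therefore estimated at 95% in this assay, within a range from 60% to 125%.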

Compound 4, largest response reached (Emax), in percent of the reference or control that the assay uses: > 19%
Compound 4: a limit, no number; the forecaster's own chance of this, stated with the estimate: 0%; the middle value does not contradict the limit.
By their numbers in this assay, from the lowest: compound 1; then compound 2; then compound 3.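

In this assay compound 4 gives > 19%, which is a limit and not a number, so the step from compound 3 to compound 4 cannot be read. The compounds shown leave open whether 4,4-dimethylcyclohexyl in place of oxan-4-yl on an aromatic nitrogen changes the maximal response, and in which direction.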